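Swapping chloro for methoxy on an aminothiophene ester

This account rests on a few compounds, and the source may have more. Where it says the series, first, only, none or still open, it means among the compounds named here.

Measured so far:
Compound 1, `COc1ccc(-c2sc(N)c(C(=O)c3ccccc3)c2-c2cccc(C(F)(F)F)c2)cc1`: 65.2%
Compound 2, `CCOC(=O)c1c(N)sc(-c2ccc(Cl)cc2)c1-c1cccc(C(F)(F)F)c1`: 58.4%

In an assay on CHO-K1 cells for displacement of a labelled ligand from adenosine receptor A1 (Homo sapiens), tested at 10 uM (on this read-out lower numbers stand for less inhibition and higher numbers for more inhibition at the one concentration tested (going by the name of the read-out)), compound 2 sits at the lower of the two numbers, and its gap to compound 1 lies within the usual scatter, so the two cannot be told apart. Compound 3, `CCOC(=O)c1c(N)sc(-c2ccc(OC)cc2)c1-c1cccc(C(F)(F)F)c1`, is not yet measured. Its difference from compound 2 is methoxy in place of chloro on an aromatic carbon. Among the measured compounds shown here, no step between measured compounds is available, so the step is expected to be small, if anything a slight rise, with the shift from compound 2 to compound 3 estimated as a number 3.6 percentage points higher from compound 2 to compound 3 (within the scatter). Compound 3 is therefore expected to give about 62%, within 45% to 78%.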

Compound 3, a percentage reported as inhibition, at one concentration (the size of the read-out at that concentration, not a potency): 81.5%
Beside the measured number, compound 3's estimate is 19.5 percentage points below it; measured number above the stated range.
By their numbers in this assay, from the lowest: compounds 2 and 1 (each within the scatter of the next); then compound 3.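

In this assay, the change from 4-chlorophenyl to 4-methoxyphenyl with the ester kept gives a number 23.1 percentage points higher from compound 2 to compound 3 (beyond the scatter), showing that this position affects the read-out, which compounds 1 and 2 could not show because they differ in more than one place. With the 4-methoxyphenyl kept, ethoxy in place of phenyl on the carbonyl carbon gives a number 16.3 percentage points higher from compound 1 to compound 3 (beyond the scatter), so that site matters as well. Nothing available accounts for either step. The compounds shown leave open how a hydroxyl, an amine or a longer alkoxy chain would read at the position of the methoxy. They also leave open whether a carboxylic acid or an amide could stand in place of the ethyl ester.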